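From morpholin-4-yl to (piperidin-1-yl)methyl on a thiocarbonyl carbon

This account rests on a few compounds, and the source may have more. Where it says the series, first, only, none or still open, it means among the compounds named here.

In a functional assay on HT-29 cells (Homo sapiens) for antiproliferative activity, read by MTT assay, with a stated time of 96 h (on this read-out higher numbers stand for weaker inhibition and lower numbers for stronger inhibition), compound 1 (`S=C(N/N=C1\CC2(CCCCC2)Oc2c1ccc1ccccc21)N1CCCCC1`) gives 6770 nM, compound 2 (`S=C(N/N=C1\CC2(CCCCC2)Oc2c1ccc1ccccc21)N1CCNCC1`) gives 8340 nM and compound 3 (`S=C(N/N=C1\CC2(CCCCC2)Oc2c1ccc1ccccc21)N1CCOCC1`) gives 9310 nM, so compound 3 stands within the scatter of both others. In compound 4 (`S=C(CN1CCCCC1)N/N=C1\CC2(CCCCC2)Oc2c1ccc1ccccc21`), (piperidin-1-yl)methyl takes the place of morpholin-4-yl on a thiocarbonyl carbon ((piperidin-1-yl)methyl in place of morpholin-4-yl on a thiocarbonyl carbon). The measured steps at that carbon, a 1.2-fold higher number from compound 1 to compound 2 (0.09 log units; within the scatter) and a 1.4-fold higher number from compound 1 to compound 3 (0.14 log units; within the scatter) and a 1.1-fold higher number from compound 2 to compound 3 (0.05 log units; within the scatter) all lie within the scatter. None of them introduces a (piperidin-1-yl)methyl group, so this evidence is indirect, and no step beyond the scatter is expected in this assay. The estimated 1.2-fold lower number from compound 3 to compound 4 (0.07 log units; within the scatter) is expected to remain within the scatter. For compound 4 the estimated value is 8000 nM (expected range 3500 nM to 18000 nM).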

Compound 4, half-maximal inhibitory concentration: 8170 nM
For compound 4 the middle estimate is 1.0-fold (0.01 log units) below the measured one; low and high end bracket the measured number.
By their numbers in this assay, from the lowest: compounds 1, 4, 2 and 3 (each within the scatter of the next).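

In this assay, compound 4 carries the only group shown on a thiocarbonyl carbon that is attached through a methyl rather than through a ring nitrogen, yet it stays within the scatter of all three others (a 1.1-fold lower number from compound 3 to compound 4 (0.06 log units; within the scatter); a 1.0-fold lower number from compound 2 to compound 4 (0.01 log units; within the scatter); a 1.2-fold higher number from compound 1 to compound 4 (0.08 log units; within the scatter)). This change therefore adds a fourth group at this place without separating any compound from the rest. No measurement offered here explains this result.

As far as these compounds go, whether a carboxylic acid, a primary amine or a longer chain on this carbon would give a step beyond the scatter remains open.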